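Emax of mGlu2 modulators: a benzyloxy piperidine variant

The compounds below may be only part of what the source reports. "The series", "measured", "known", "first", "only" and "open" are said of these compounds alone.

Measured compounds:
compound 1, `Fc1ccccc1C1CCN(Cc2ccn3c(CC4CC4)nnc3c2C(F)(F)F)CC1`, 353%
compound 2, `FC(F)(F)c1c(CN2CCC(c3ccccc3Cl)CC2)ccn2c(CC3CC3)nnc12`, 328%

Compound 1 stands highest of the two numbers in an assay on CHO cells for positive allosteric modulation of metabotropic glutamate receptor 2 (Homo sapiens), read by scintillation counting, with a stated time of 30 min; a lower number here means a smaller maximal response, a higher number a larger maximal response; its nearest neighbour is compound 2, and that step, a number 25 percentage points lower from compound 1 to compound 2 (beyond the scatter), came with chloro in place of fluoro on an aromatic carbon. Compound 3 is `Fc1ccc(COC2CCN(Cc3ccn4c(CC5CC5)nnc4c3C(F)(F)F)CC2)c(F)c1`, not yet measured in this assay. It differs from compound 1 as follows: (2,4-difluorobenzyl)oxy in place of 2-fluorophenyl on a saturated ring carbon. Among the compounds with values here, no measured step bears on this change; the only step known is a halogen swap on the aromatic ring, of modest size, and it says nothing about replacing the whole 2-fluorophenyl group with (2,4-difluorobenzyl)oxy. The expectation therefore rests on compound 1 alone, with wide uncertainty, and a step of a number 63 percentage points lower from compound 1 to compound 3 (beyond the scatter) is estimated, leaning downward. Compound 3 is expected to give about 290%, within 190% to 380%.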

Compound 3, largest response reached (Emax), in percent of the reference or control that the assay uses in the metabotropic glutamate receptor 2 assay: 332%
Beside the measured number, compound 3's estimate is 42 percentage points below it; measured number inside the range.
By their numbers in the metabotropic glutamate receptor 2 assay, from the lowest: compounds 2 and 3 (each within the scatter of the next); then compound 1.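

In the metabotropic glutamate receptor 2 assay, the change gave a number 21 percentage points lower from compound 1 to compound 3 (beyond the scatter), while the other comparison gave a number 4 percentage points higher from compound 2 to compound 3 (within the scatter). This position on a saturated ring carbon therefore tolerates more than a halogen swap on the aromatic ring: with (2,4-difluorobenzyl)oxy in place of the 2-halophenyl groups, the maximal response stays at the level of compound 2 and only modestly short of compound 1. In a physicochemical assay for solubility, read by HPLC, measured as kinetic solubility, at pH 7 (a lower number here means a less soluble compound, a higher number a more soluble compound), compound 1 gives 2000 nM and compound 3 gives 3000 nM, values within the usual scatter of each other, so the change leaves no readable mark on that measure.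

Nothing available explains why the response holds up across this change. The compounds shown leave open whether the ether oxygen matters, and how an amide or an amine in its place would read.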